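This account rests on a few compounds, and the source may have more. Where it says the series, first, only, none or still open, it means among the compounds named here.

In a functional assay on HeLa cells (Homo sapiens) for antiproliferative activity, read by sulforhodamine B assay, with a stated time of 48 h (a higher number here means a weaker inhibitor of growth, a lower number a stronger inhibitor of growth), compound 1 (`COc1ccc(-c2cn(CCCN3C(=O)COc4ccccc43)nn2)cc1`) gives 4900 nM, and compound 2 (`CCCc1cn(CCCN2C(=O)COc3ccccc32)nn1`) gives 23200 nM, the higher of the two numbers and so the weaker inhibitor of growth. Compound 3 (`O=C1COc2ccccc2N1CCCn1cc(CCCCl)nn1`) turns the propyl of compound 2 into 3-chloropropyl: chloro in place of hydrogen on a saturated chain carbon, three bonds along the chain from an aromatic carbon. This places chloro in place of hydrogen on a saturated chain carbon, three bonds along the chain from an aromatic carbon. Among the compounds with values here, the only measured step that bears on this is a 4.7-fold higher number from compound 1 to compound 2 (0.68 log units; beyond the scatter), with propyl in place of 4-methoxyphenyl on an aromatic carbon, a modest step beyond the scatter. The new change is much smaller than that swap, so a smaller step is expected in this assay, probably within the scatter, with only a slight lean toward a lower number. The data give no firm direction. For compound 3 the expected value is 18000 nM, with an estimated range of 8000 nM to 40000 nM. That estimate means an expected 1.3-fold lower number from compound 2 to compound 3 (0.11 log units; within the scatter).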

Compound 3, concentration for 50% growth inhibition: 100 nM
For compound 3 the middle estimate is 180-fold (2.26 log units) above the measured one, and the stated range ends above it.
By their numbers in this assay, from the lowest: compound 3; then compound 1; then compound 2.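

In this assay a single chloro in place of hydrogen on a saturated chain carbon, three bonds along the chain from an aromatic carbon, gives a 230-fold lower number from compound 2 to compound 3 (2.37 log units; beyond the scatter), a far larger step than the earlier swap of a whole group, a 4.7-fold higher number from compound 1 to compound 2 (0.68 log units; beyond the scatter). That earlier swap made propyl look like a poor replacement for 4-methoxyphenyl, yet 3-chloropropyl in place of 4-methoxyphenyl gives a 49-fold lower number from compound 1 to compound 3 (1.69 log units; beyond the scatter), so among these three compounds a chain in this place can beat the aromatic group, provided it carries the chloro. Nothing available explains this jump.

From the compounds shown here alone, it remains open whether the gain belongs to chloro alone or would also appear with a bromo, a hydroxyl or an amine in the same place. Also open, going by these compounds, is how the result depends on chain length, as in 2-chloroethyl, chloromethyl or a longer chain.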